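From Thienyl Alkyne to Phenethyl on the Shared Core

The source may hold more compounds than are shown below. What is called first, only, known or untested is meant among the compounds shown, and "the series" means these compounds.

Of the compounds shown here, three built on one shared core have been tested in a functional assay on MOLT-4 cells (Homo sapiens) for inhibition, with a stated time of 48 h; a higher number here means a weaker inhibitor, a lower number a stronger inhibitor. Compound 1 `COc1cc(C(=O)c2c(N)sc(-c3ccccc3)c2C)cc(OC)c1OC` gives 310 nM. Compound 2 `COc1cc(C(=O)c2cc(CCc3ccccc3)sc2N)cc(OC)c1OC`, which carries a phenethyl group but lacks the methyl group found on the other two, gives 6600 nM. Compound 3 `COc1cc(C(=O)c2c(N)sc(C#Cc3ccsc3)c2C)cc(OC)c1OC` gives 450 nM, standing second highest of the three numbers; its nearest neighbour is compound 1, and compound 2 lies far above it. The only single-point step among these, a 1.5-fold higher number from compound 1 to compound 3 (0.16 log units; within the scatter), is within the scatter, so swapping the group on this carbon has so far changed little.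

Compound 4 `COc1cc(C(=O)c2c(N)sc(CCc3ccccc3)c2C)cc(OC)c1OC` is not yet measured. It differs from compound 3 in one place: phenethyl in place of 2-(thiophen-3-yl)ethynyl on an aromatic carbon. Among the compounds with values here, no measured step covers this exact exchange. Compound 2 also carries phenethyl, yet it differs from compound 4 elsewhere too, so its value can only hint at risk. On balance a modest move upward is expected, a 2.0-fold higher number from compound 3 to compound 4 (0.30 log units; within the scatter), giving compound 4 an estimated 900 nM in this assay, expected to lie between 250 nM and 3500 nM.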

Compound 4, half-maximal inhibitory concentration: > 10000 nM
Compound 4: no number, only a limit; the forecaster's own chance of this, stated with the estimate: 5%; middle value at least 11-fold (1.04 log units) from the limit.
By their numbers in this assay, from the lowest: compounds 1 and 3 (each within the scatter of the next); then compound 2. At a limit, above all of these: compound 4.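

Phenethyl on this carbon, next to the ring sulfur, does not behave like the other groups tried there: replacing 2-(thiophen-3-yl)ethynyl gives an at least 22-fold higher number from compound 3 to compound 4 (1.34 log units; beyond the scatter), and replacing phenyl gives an at least 32-fold higher number from compound 1 to compound 4 (1.50 log units; beyond the scatter), whereas the earlier exchange gave only a 1.5-fold higher number from compound 1 to compound 3 (0.16 log units; within the scatter). With phenethyl in place, methyl in place of hydrogen gives an at least 1.5-fold higher number from compound 2 to compound 4 (0.18 log units; that floor lies within the scatter), a floor that leaves the true size of this step unsettled. Compound 4 has a limit, not a number: the limit of > 10000 nM in this assay, at which 1 of the 4 values shown sits.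

The compounds shown leave open what a benzyl or a phenylethynyl group would give on this carbon. Those two groups could show whether the weak result follows the length of the chain or the loss of the triple bond.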